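The source may hold more compounds than are shown below. What is called first, only, known or untested is meant among the compounds shown, and "the series" means these compounds.

Compound 1 `Cc1nc(Cl)sc1S(=O)(=O)N1CCC(N2CCC(C)CC2)CC1` is one of three compounds tested in an ADME assay on HCT-116 cells (Homo sapiens) for cytotoxicity, read by CellTiter-Glo, with a stated time of 72 h; a lower number here means a stronger inhibitor, a higher number a weaker inhibitor. Going by the values given here, compound 1 reaches only a limit there, > 10000 nM, and the limit of > 10000 nM in this assay, at which 1 of the 3 values shown sits, marks it as the single value at that point. Compound 2 `CC1CCN(C2CCN(S(=O)(=O)c3cc(F)c(Br)c(F)c3)CC2)CC1` also stops at a limit in this assay, > 5000 nM. Compound 3 `Cc1cc(C)c(S(=O)(=O)NC2CCN(C3CCN(C)CC3)CC2)c(C)c1` likewise gives only a limit in this assay, > 5000 nM, and the limit of > 5000 nM in this assay, at which 2 of the 3 values shown sit, gathers these two. Among the compounds with values here, with no measured number among the three, no step between them can be sized. Compound 4 `CC1CCN(C2CCN(S(=O)(=O)c3cncc(Br)c3)CC2)CC1` differs from compound 1 by 5-bromopyridin-3-yl in place of 2-chloro-4-methyl-1,3-thiazol-5-yl on a sulfonyl sulfur. Given compound 1 rests at > 10000 nM, the expected step is a step that the limit leaves unreadable from compound 1 to compound 4, nothing beyond the scatter. Compound 4 is therefore estimated at 15000 nM in this assay, within 5000 nM to 50000 nM, most probably reported again as a limit.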

Compound 4, half-maximal inhibitory concentration: > 10000 nM
Compound 4 ended at the assay's limit; the forecaster's own chance of this, stated with the estimate: 85%; the middle value does not contradict the limit.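

Compound 1 and compound 4 both stop at a limit in this assay, so the step between them cannot be read. The compounds shown leave open whether 5-bromopyridin-3-yl and 2-chloro-4-methyl-1,3-thiazol-5-yl differ in effect on these cells.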